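A methoxy step from compound 2 to compound 3

The source may hold more compounds than are shown below. What is called first, only, known or untested is meant among the compounds shown, and "the series" means these compounds.

In a functional assay on A549 cells (Homo sapiens) for antiproliferative activity, with a stated time of 72 h (a lower number here means a stronger inhibitor, a higher number a weaker inhibitor), compound 1 (`COc1ccc(C2CC(c3ccccc3)=NN2c2nc(-c3ccccc3)c(C#N)c(=O)n2C)cc1`) gives 1760 nM and compound 2 (`Cn1c(N2N=C(c3ccccc3)CC2c2ccccc2)nc(-c2ccc(Cl)cc2)c(C#N)c1=O`) gives 28100 nM, the higher of the two numbers and beyond the scatter from compound 1. Compound 3 (`COc1ccc(C2CC(c3ccccc3)=NN2c2nc(-c3ccc(Cl)cc3)c(C#N)c(=O)n2C)cc1`) has methoxy in place of hydrogen on an aromatic carbon of compound 2 (methoxy in place of hydrogen on an aromatic carbon), turning phenyl to 4-methoxyphenyl. Compound 1, which also carries 4-methoxyphenyl, gives 1760 nM in this assay, so a fall beyond the scatter is expected, although compound 1 differs elsewhere too. The expected size is an estimated 5.6-fold lower number from compound 2 to compound 3 (0.75 log units; beyond the scatter) in this reading. For compound 3 the estimate is 5000 nM (expected range 1500 nM to 15000 nM).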

Compound 3, half-maximal inhibitory concentration: 23800 nM
Compound 3: middle estimate off by 4.8-fold (0.68 log units), on the low side; measured number outside the range, above it.
By their numbers in this assay, from the lowest: compound 1; then compounds 3 and 2 (each within the scatter of the next).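

In this assay, the change from phenyl to 4-methoxyphenyl gives a 1.2-fold lower number from compound 2 to compound 3 (0.07 log units; within the scatter), so with chloro present, this position shows no effect of methoxy beyond the scatter. The chloro change gives a 14-fold higher number from compound 1 to compound 3 (1.13 log units; beyond the scatter), which shows that with 4-methoxyphenyl in place, chloro accounts for a large difference. No measured evidence bears on the reason for either result. The compounds shown leave open whether methoxy would have the same effect without chloro. They also leave open how a hydroxyl or an amine would compare with methoxy at this position.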